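Pyridin-4-yl Replaces Cyclopropylphenyl on a Thiazole Cinnamamide

The compounds below may be only part of what the source reports. "The series", "measured", "known", "first", "only" and "open" are said of these compounds alone.

Measured compounds in a functional assay on K562 cells (Homo sapiens) for inhibition, read by MTT assay, with a stated time of 96 h; a lower number here means a stronger inhibitor, a higher number a weaker inhibitor:
Compound 1 `Cc1ccc(/C=C/C(=O)Nc2nc(-c3c(C)cc(C)cc3C)cs2)cc1` gives 7880 nM.
Compound 2 `Cc1cc(C)c(-c2csc(NC(=O)/C=C/c3ccc([N+](=O)[O-])cc3)n2)c(C)c1` gives 32200 nM.
Compound 3 `Cc1cc(C)c(-c2csc(NC(=O)/C=C/c3ccc(C4CC4)cc3)n2)c(C)c1` gives 380 nM.

Compound 3 holds the lowest number of the three: a 21-fold lower number from compound 1 to compound 3 (1.32 log units; beyond the scatter) and an 85-fold lower number from compound 2 to compound 3 (1.93 log units; beyond the scatter), both beyond the scatter, while the step of a 4.1-fold higher number from compound 1 to compound 2 (0.61 log units; beyond the scatter) is the modest one among them.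

Compound 4 `Cc1cc(C)c(-c2csc(NC(=O)/C=C/c3ccncc3)n2)c(C)c1` differs from compound 3 in one place: pyridin-4-yl in place of 4-cyclopropylphenyl on a double-bonded chain carbon bound to a double-bonded chain carbon. The cyclopropyl group is not merely swapped for another substituent here; the whole 4-cyclopropylphenyl group leaves and an unsubstituted heteroaryl enters.

Going by the values given here, the steps that bear on this are those ending in compound 3, a 21-fold lower number from compound 1 to compound 3 (1.32 log units; beyond the scatter) and an 85-fold lower number from compound 2 to compound 3 (1.93 log units; beyond the scatter), which show that the cyclopropyl group accounts for the low number of compound 3. Among the compounds with values here, its loss is therefore expected to raise the number in this assay by a large step, with no measured step showing how pyridin-4-yl itself compares. For compound 4 the expected step is a 32-fold higher number from compound 3 to compound 4 (1.50 log units; beyond the scatter), placing the estimate at 12000 nM, with a range from 2000 nM to 60000 nM.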

Compound 4, half-maximal inhibitory concentration: 9390 nM
For compound 4 the middle estimate is 1.3-fold (0.11 log units) above the measured one; the measured number falls inside the stated range.
By their numbers in this assay, from the lowest: compound 3; then compounds 1 and 4 (each within the scatter of the next); then compound 2.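

In this assay the exchange of the whole 4-cyclopropylphenyl group for pyridin-4-yl gives a 25-fold higher number from compound 3 to compound 4 (1.39 log units; beyond the scatter) and so costs about as much as the loss of cyclopropyl alone. Set against the other two compounds, the same group gives a 1.2-fold higher number from compound 1 to compound 4 (0.08 log units; within the scatter) and a 3.4-fold lower number from compound 2 to compound 4 (0.54 log units; beyond the scatter), so pyridin-4-yl cannot be told apart from 4-methylphenyl here but still gives a lower number than 4-nitrophenyl. The earlier compounds shown here changed only a substituent on a phenyl ring, whereas this result shows that an unsubstituted heteroaryl at this place can match the methyl compound without approaching compound 3.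

Nothing available explains the size or direction of these steps. Going by these compounds, it remains open whether a cyclopropyl group carried on the pyridin-4-yl group would restore the low number, and how an amine or a longer alkyl chain on the phenyl ring would compare.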